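The compounds below may be only part of what the source reports. "The series", "measured", "known", "first", "only" and "open" are said of these compounds alone.

compound 1 `Cc1ccccc1-c1nn(-c2ccc(Br)cc2)cc1CNCCN1CCN(C)CC1` — 9600 nM
compound 2 `CN1CCN(CCNCc2cn(-c3ccc(F)cc3F)nc2-c2cccc(N(C)C)c2)CC1` — > 20000 nM
compound 3 `Cc1ccccc1-c1nn(-c2ccc(F)cc2F)cc1CN1CCC(N2CCCCC2)CC1` — > 20000 nM

All three compounds were tested in an ADME assay on Huh-7 cells (Homo sapiens) for cytotoxicity; a lower number here means that less compound is tolerated, a higher number that more compound is tolerated. Going by the values given here, compound 1 gives 9600 nM, the only real number among the three. For compound 2 the value > 20000 nM is a limit of the assay rather than a number. For compound 3 the value > 20000 nM is likewise a limit. Compound 1 therefore stands alone with a measured number, and that number sits not far from the limit of > 20000 nM in this assay, at which 2 of the 3 values shown sit.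

The unmeasured compound 4 `Cc1ccccc1-c1nn(-c2ccc(F)c(F)c2)cc1CNCCN1CCN(C)CC1` differs from compound 1 in one place: 3,4-difluorophenyl in place of 4-bromophenyl on an aromatic nitrogen. Among the compounds with values here, no measured pair shares this change, so no measured step tells how large its effect is. Among the three measured compounds, two sit at the limit and compound 1 sits within reach of it, so in this assay a step from compound 1 of no more than the usual scatter is expected, in either direction, with a fair chance that compound 4 also ends at the limit. Compound 4 is estimated at 15000 nM, with a range from 6000 nM to 40000 nM. That estimate means an expected step of a 1.6-fold higher number from compound 1 to compound 4 (0.19 log units; within the scatter), lying within the scatter.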

Compound 4, half-maximal cytotoxic concentration: > 20000 nM
Compound 4: a limit, no number; the forecaster's own chance of this, stated with the estimate: 40%; at least 1.3-fold (0.12 log units) between middle value and limit.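

In this assay, putting 3,4-difluorophenyl in place of 4-bromophenyl on the aromatic nitrogen gives an at least 2.0-fold higher number from compound 1 to compound 4 (0.31 log units; beyond the scatter). Compound 4 shows > 20000 nM, which is a limit and not a number, so this single change sets a lowest possible size for the step and leaves its true size unknown. This is the first step at this position, and it shows that the group on this nitrogen can by itself move the result beyond the scatter, leaving compound 1 as the only compound here with a real number and so the one least tolerated by the cells, while the others cannot be ranked against each other: the limit of > 20000 nM in this assay, at which 3 of the 4 values shown sit.

The swap removes the bromine and brings in two fluorines at once, so the compounds shown leave open which of these matters, and a plain phenyl or a 4-chlorophenyl group on the same nitrogen of the core of compound 1 would help to separate the two. As far as these compounds go, how far compound 4 really lies from compound 1 also stays open, as any value past the limit would fit what is printed.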